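A Third Methoxy on the Benzyl Ring

This account rests on a few compounds, and the source may have more. Where it says the series, first, only, none or still open, it means among the compounds named here.

Three amides sharing one core have been tested in a functional assay on MIA PaCa-2 cells (Homo sapiens) for antiproliferative activity, read by sulforhodamine B assay, with a stated time of 48 h; on this read-out higher numbers stand for weaker inhibition of growth and lower numbers for stronger inhibition of growth. Compound 1 `O=C(NCc1cn(Cc2ccc(F)cc2)nn1)c1cn(-c2ccccc2)nc1-c1ccccc1` gives 9600 nM. Compound 2 `O=C(NCc1cn(Cc2ccc(Cl)cc2)nn1)c1cn(-c2ccccc2)nc1-c1ccccc1` gives 8700 nM, and compound 3 `COc1ccc(Cn2cc(CNC(=O)c3cn(-c4ccccc4)nc3-c3ccccc3)nn2)cc1OC` gives 8200 nM, the lowest of the three numbers, though every gap between them is within the scatter: a 1.1-fold lower number from compound 1 to compound 2 (0.04 log units; within the scatter), a 1.2-fold lower number from compound 1 to compound 3 (0.07 log units; within the scatter) and a 1.1-fold lower number from compound 2 to compound 3 (0.03 log units; within the scatter). Compound 4 `COc1cc(Cn2cc(CNC(=O)c3cn(-c4ccccc4)nc3-c3ccccc3)nn2)cc(OC)c1OC` differs from compound 3 by methoxy in place of hydrogen on an aromatic carbon. The changes already seen on the same benzyl ring are the ones that bear on this step, and none of them moved the number beyond the scatter. Compound 4 is therefore expected to show a step of a 1.1-fold lower number from compound 3 to compound 4 (0.04 log units; within the scatter), nothing beyond the scatter. Compound 4 is estimated at 7500 nM, within a range from 3000 nM to 20000 nM.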

Compound 4, concentration for 50% growth inhibition: 1000 nM
Compound 4: the middle estimate sits 7.5-fold (0.88 log units) above what was measured; the whole stated range lies above it.
By their numbers in this assay, from the lowest: compound 4; then compounds 3, 2 and 1 (each within the scatter of the next).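

In this assay the earlier changes on the benzyl ring stayed within the scatter, but adding one methoxy to the 3,4-dimethoxyphenyl ring gives an 8.2-fold lower number from compound 3 to compound 4 (0.91 log units; beyond the scatter) on this read-out. The 3,4,5-trimethoxyphenyl group also stands apart from the 4-chlorophenyl and 4-fluorophenyl groups, with an 8.7-fold lower number from compound 2 to compound 4 (0.94 log units; beyond the scatter) and a 9.6-fold lower number from compound 1 to compound 4 (0.98 log units; beyond the scatter) as the steps, so this ring can move the number beyond the scatter. No measurement available here explains this gain. Still open, as far as these compounds go, is whether an ethoxy or a hydroxyl group on that same aromatic carbon would give a similar step, or whether methoxy itself is needed.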